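Swapping 3-(1-hydroxyethyl)phenyl for 1H-benzimidazol-6-yl

The source may hold more compounds than are shown below. What is called first, only, known or untested is meant among the compounds shown, and "the series" means these compounds.

Measured in a physicochemical assay for solubility; a higher number here means a more soluble compound, a lower number a less soluble compound:
Compound 1 `CNC(=O)c1cc(C(=O)NC2CC2)c(C)n(Cc2ccccc2)c1=O`: >= 126 ug/mL, a limit.
Compound 2 `CNC(=O)c1cc(C(=O)NC2CC2)cn(Cc2cccc3[nH]ccc23)c1=O`: 78 ug/mL.
Compound 3 `CNC(=O)c1cc(C(=O)NC2CC2)cn(Cc2cccc([C@@H](C)O)c2)c1=O`: >= 131 ug/mL, a limit.

Compound 3 has no exact number in this assay, only the limit >= 131 ug/mL. Compound 4 `CNC(=O)c1cc(C(=O)NC2CC2)cn(Cc2ccc3nc[nH]c3c2)c1=O` is still unmeasured, and its change from compound 3 is 1H-benzimidazol-6-yl in place of 3-(1-hydroxyethyl)phenyl on a saturated chain carbon bound to an aromatic nitrogen. For the measured compounds named here, one measured step bears on this, an at least 1.6-fold higher number from compound 2 to compound 3 (0.22 log units; that floor lies within the scatter), where 3-(1-hydroxyethyl)phenyl replaces 1H-indol-4-yl. The entering group, like 1H-indol-4-yl, has a five-membered and a six-membered aromatic ring. Compound 4 is therefore expected to land near compound 2, which gives 78 ug/mL. The expected change is small and downward, an at least 1.4-fold lower number from compound 3 to compound 4 (0.16 log units; that floor lies within the scatter). The estimate for compound 4 is 90 ug/mL, with an expected range from 40 ug/mL to 180 ug/mL.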

Compound 4, solubility: >= 163 ug/mL
Compound 4: no number, only a limit (the forecaster's own chance of this, stated with the estimate: 25%); at least 1.8-fold (0.25 log units) between middle value and limit.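

In this assay, compound 4 gives a limit rather than a number: the limit of >= 163 ug/mL in this assay, at which 1 of the 4 values shown sits. Putting 1H-benzimidazol-6-yl in place of 1H-indol-4-yl gives an at least 2.0-fold higher number from compound 2 to compound 4 (0.32 log units; beyond the scatter), so at this place, on a saturated chain carbon bound to an aromatic nitrogen, a group with a five-membered and a six-membered aromatic ring need not keep the reading as low as in compound 2. The step from compound 3 to compound 4 cannot be read, as both values are limits.

On these data alone, how far compound 3 and compound 4 actually lie past their limits stays open. So does what an amine or a carboxylic acid at this place would give in this assay.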